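This account rests on a few compounds, and the source may have more. Where it says the series, first, only, none or still open, it means among the compounds named here.

Compound 2 `Cc1cccc(C)c1NN=C1CCC(C)n2c1ncc(C(=O)O)c2=O` was tested in a functional assay on the whole organism with Rattus norvegicus as the target (on this read-out higher numbers stand for an effect only at larger amounts of compound and lower numbers for an effect already at smaller amounts), and gave 320 umol/kg. Compound 3 `Cc1cc(C)c(NN=C2CCC(C)n3c2ncc(C(=O)O)c3=O)c(C)c1` gave 320 umol/kg in this assay, so the step of no change at the digits printed from compound 2 to compound 3 (within the scatter) lies within the scatter and compound 2 stands level with compound 3. Compound 1 `Cc1cc(C)cc(NN=C2CCC(C)n3c2ncc(C(=O)O)c3=O)c1` reached only a limit of this assay, > 320 umol/kg. The step of a number no higher from compound 1 to compound 2 (the limit leaves the size open) has no readable size for that reason. Compound 4 `CC1CCC(=NNc2c(Cl)cccc2Cl)c2ncc(C(=O)O)c(=O)n21` differs from compound 2 by 2,6-dichlorophenyl in place of 2,6-dimethylphenyl on an amine nitrogen. Neither measured step replaces methyl with chlorine, so none bears directly on this change; the steps that were measured showed no shift beyond the scatter, and none beyond the scatter is expected in this assay here either. The expected step of no change at the digits printed from compound 2 to compound 4 (within the scatter) is accordingly small. Compound 4 is estimated at 320 umol/kg, between 100 umol/kg and 1000 umol/kg.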

Compound 4, dose for 50% inhibition: > 100 umol/kg
Compound 4 was reported as a limit; the forecaster's own chance of this, stated with the estimate: 40%; the middle value does not contradict the limit.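

Going by these compounds alone, compound 4 gave only a limit, > 100 umol/kg, so no step from compound 2 or compound 1 to compound 4 can be read. The compounds shown leave open whether 2,6-dichlorophenyl and 2,6-dimethylphenyl differ at all in this assay.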